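The compounds below may be only part of what the source reports. "The series", "measured", "known", "first", "only" and "open" are said of these compounds alone.

Measured compounds in a physicochemical assay for solubility, read by HPLC, at pH 6.8; on this read-out lower numbers stand for lower solubility and higher numbers for higher solubility:
- compound 1 `CC(C)(C)c1cc(NC(=O)[C@@H]2CCCCN2C2CC2)no1` gives 38 ug/mL
- compound 2 `CC(C)(C)c1cc(NC(=O)[C@@H]2CCCCN2C2CCOCC2)no1` gives 74 ug/mL
- compound 3 `CC(C)(C)c1cc(NC(=O)[C@@H]2CCCCN2CC2CCOCC2)no1` gives 72 ug/mL

Compound 3 sits with compound 2 at the upper end of these three numbers; the gap between them is a 1.0-fold lower number from compound 2 to compound 3 (0.01 log units; within the scatter), and the gap from compound 1 is a 1.9-fold higher number from compound 1 to compound 3 (0.28 log units; within the scatter). Among the compounds with values here, none of the measured steps leaves the scatter, so the three compounds are not separated on this read-out.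

Compound 4 `CC(C)(C)c1cc(NC(=O)[C@@H]2CCCCN2C(=O)c2ccccc2)no1` differs from compound 3 by benzoyl in place of (oxan-4-yl)methyl on an amine nitrogen in a ring.

The measured steps all swap one saturated substituent on that ring nitrogen for another: a 1.9-fold higher number from compound 1 to compound 2 (0.29 log units; within the scatter), a 1.9-fold higher number from compound 1 to compound 3 (0.28 log units; within the scatter) and a 1.0-fold lower number from compound 2 to compound 3 (0.01 log units; within the scatter). None of them puts an aromatic ring or a carbonyl on that nitrogen, so none bears directly on the change to compound 4. They show only that this position has so far been tolerant, with every step inside the scatter. Within the data shown here, with no guiding step, the expectation for compound 4 is set near the middle of the measured range, with a wide band to allow for an untested kind of substituent.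

Compound 4 is therefore expected to give about 40 ug/mL in this assay, within 10 ug/mL to 130 ug/mL, which would mean an estimated step of a 1.8-fold lower number from compound 3 to compound 4 (0.26 log units; within the scatter).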

Compound 4, solubility: 0.9 ug/mL
The estimate for compound 4 lay 44-fold (1.65 log units) above the measured number; measured number outside the range, below it.
By their numbers in this assay, from the lowest: compound 4; then compounds 1, 3 and 2 (each within the scatter of the next).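

In this assay this position proves sensitive to the kind of substituent on the ring nitrogen: benzoyl in place of (oxan-4-yl)methyl gives an 80-fold lower number from compound 3 to compound 4 (1.90 log units; beyond the scatter) and benzoyl in place of oxan-4-yl gives an 82-fold lower number from compound 2 to compound 4 (1.91 log units; beyond the scatter) while benzoyl in place of cyclopropyl gives a 42-fold lower number from compound 1 to compound 4 (1.63 log units; beyond the scatter) in the same direction. All three steps lie beyond the scatter, whereas every step among the saturated substituents stayed within it, so compound 4 stands apart from compound 1, compound 2 and compound 3 alike. The tolerance seen earlier therefore holds only for those three saturated groups and does not extend to benzoyl.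

Benzoyl brings an aromatic ring of carbon only and a carbonyl onto that nitrogen together, so the compounds shown leave open which of the two goes with the drop, a question that a benzyl group and an acetyl group on the same nitrogen would take apart. No measurement shown speaks to the cause of the drop.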